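Ortho-Fluoro to Para-Chloro on the Benzamide of Compound 2

This account rests on a few compounds, and the source may have more. Where it says the series, first, only, none or still open, it means among the compounds named here.

Measured compounds:
compound 2, `CN1CCN(c2ccc(Nc3nc(-c4cccc(NC(=O)c5ccccc5F)c4)sc3C(N)=O)cc2)CC1`: 1360 nM
compound 1, `CN1CCN(c2ccc(Nc3nc(-c4cccc(NC(=O)c5cccc(F)c5)c4)sc3C(N)=O)cc2)CC1`: "not determined" (no result reported)

Within the data shown here, compound 2 is the only compound of this series with a number in a functional assay on Ramos cells (Homo sapiens) for antiproliferative activity, read by CCK-8 assay, with a stated time of 72 h; on this read-out lower numbers stand for stronger inhibition and higher numbers for weaker inhibition: there compound 2 gives 1360 nM. Among the measured compounds shown here, compound 1 shares the core of compound 2 and carries a 3-fluorophenyl group on the same carbonyl carbon; in this assay compound 1 gives "not determined" (no result reported), so no step between measured compounds exists and compound 2 stands alone.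

Compound 3, `CN1CCN(c2ccc(Nc3nc(-c4cccc(NC(=O)c5ccc(Cl)cc5)c4)sc3C(N)=O)cc2)CC1`, is the next compound to be tested. It differs from compound 2 in one place: 4-chlorophenyl in place of 2-fluorophenyl on a carbonyl carbon. Without any measured pair to lean on, the size of the step in this assay cannot be read from earlier numbers; no change beyond the usual scatter is expected in either direction, and compound 3 is estimated to stay close to compound 2, with the step of a 1.2-fold lower number from compound 2 to compound 3 (0.09 log units; within the scatter). For compound 3 the estimate is 1100 nM, with a range from 300 nM to 4000 nM.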

Compound 3, half-maximal inhibitory concentration: 1360 nM
Estimate against measurement, compound 3: 1.2-fold (0.09 log units) below, and the stated range covers the measured number.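

Among these compounds, replacing 2-fluorophenyl with 4-chlorophenyl on the carbonyl carbon gives the first step that can be read at this position in this assay: no change at the digits printed from compound 2 to compound 3 (within the scatter). Among the compounds shown here, the exchange alters both the halogen and its place on the phenyl ring, yet the two groups cannot be told apart in this read-out, so this one position now has a first reading in place of a lone number. No data are available here to explain this result.

The step involving compound 1, with its 3-fluorophenyl group, cannot be read, and because the halogen and its place changed together, the two compounds with numbers cannot separate one from the other, a question that a 4-fluorophenyl or a 2-chlorophenyl group would address. On these data alone, it also remains open whether an unsubstituted phenyl, a 4-methoxyphenyl, a 4-(dimethylamino)phenyl or a 4-carboxyphenyl group on the same carbonyl carbon would move the number beyond the scatter in either direction.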